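This account rests on a few compounds, and the source may have more. Where it says the series, first, only, none or still open, it means among the compounds named here.

In an assay on isolated protein for inhibition of DNA topoisomerase 1 (Homo sapiens) (on this read-out lower numbers stand for stronger inhibition and higher numbers for weaker inhibition), three compounds have been tested so far. Compound 1 `O=C(Nc1ccc(NC(=O)c2cc(O)c(O)c(O)c2)cc1)c1cc(O)c(O)c(O)c1` gives 1400 nM, the only result that is a number rather than a limit. Compound 2 `O=C(Nc1ccc(NC(=O)c2ccc(O)cc2)cc1)c1ccc(O)cc1` gives only the limit > 100000 nM, which means the assay reports no number for it. Compound 3 `O=C(Nc1nc2ccccc2s1)c1ccc(O)cc1` likewise gives only the limit > 100000 nM. Compound 3 therefore stands at the limit of > 100000 nM in this assay, at which 2 of the 3 values shown sit, so no real number marks its place, and nothing can be said about how it ranks against compound 2.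

Compound 4 `O=C(Nc1nc2ccccc2s1)c1ccc(O)c(O)c1` keeps the whole of compound 3 and changes it in one place: hydroxy in place of hydrogen on an aromatic carbon. For the measured compounds named here, no pair among the measured compounds differs by exactly this change, so there is no measured step to lean on. Going by the values given here, compound 1, whose amide bears the hydroxy-rich ring, is the only compound to give a number, but it differs from compound 4 in more than one place and so cannot be read as a direct guide.

The expectation for compound 4 is a modest gain over compound 3 in this assay, a step of an at least 2.0-fold lower number from compound 3 to compound 4 (0.30 log units; that floor lies within the scatter), though it could well stay at the limit. The estimate for compound 4 is 50000 nM, within a range from 10000 nM to 200000 nM.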

Compound 4, half-maximal inhibitory concentration: 16900 nM
For compound 4 the middle estimate is 3.0-fold (0.47 log units) above the measured one, within the range that was stated.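

In this assay, placing one hydroxy group on the aromatic ring of compound 3 gives an at least 5.9-fold lower number from compound 3 to compound 4 (0.77 log units; beyond the scatter). For the compounds shown here, that size is only a floor, since one end of the step is a limit and not a number: the limit of > 100000 nM in this assay, at which 2 of the 4 values shown sit. Even so, the step shows what the earlier compounds could not, as none of them differ in just one place: at this carbon, ortho to a hydroxy group and meta to a large group, this single change is enough to turn a limit into a real number on this core.

Going by these compounds, it remains open whether the gain depends on the hydroxy group itself, or whether a methoxy group, an amine or a fluorine atom on the same carbon would do as well. On these data alone, it is also open whether a further hydroxy group on the same ring of compound 4, giving a ring like those in compound 1, would lower the number again on this core.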